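The source may report more compounds than this note shows. Statements on the series, on what has been measured and on what is new or still open speak of the compounds shown alone.

The measured compounds are compound 1 `Cc1ccc(C(=O)CCc2nnc(-c3ccccc3)o2)cc1`, which in a functional assay on the whole organism (strain Wistar) for inhibition, with Rattus norvegicus as the target, with stated times of 30 min and 2 h, at a dose of 20 mg/kg by the oral route (on this read-out higher numbers stand for more inhibition at the one dose given (going by the name of the read-out) and lower numbers for less inhibition), gives 33.3%; compound 2 `Cc1ccc(C(=O)CCc2nnc(-c3ccccc3)o2)c(C)c1`, which gives 36%; and compound 3 `COc1ccc(-c2nnc(CCC(=O)c3ccc(C)cc3C)o2)cc1OC`, which gives 58.7%.

Compound 2 stands second highest of these three numbers. For the measured compounds named here, the only single-change step, a number 2.7 percentage points higher from compound 1 to compound 2 (within the scatter), lies within the scatter, so compounds 1 and 2 cannot be ordered. Compound 3 gives a number beyond the scatter above compound 2.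

Compound 4 `Cc1ccc(C(=O)CCc2nnc(COc3ccccc3)o2)c(C)c1` differs from compound 2 in one place: phenoxymethyl in place of phenyl on an aromatic carbon. Going by the values given here, no measured step touches an exchange of this kind; the one step seen concerns a methyl only. With nothing to suggest a shift, the expected step is no change at the digits printed from compound 2 to compound 4 (within the scatter). Compound 4 is therefore estimated at 36%, within 22% to 52%.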

Compound 4, a percentage reported as inhibition, in the whole organism at one dose (the size of the read-out at that dose, not a potency): 27.6%
Compound 4: the middle estimate sits 8.4 percentage points above what was measured; low and high end bracket the measured number.
By their numbers in this assay, from the lowest: compounds 4, 1 and 2 (each within the scatter of the next); then compound 3.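

In this assay, phenoxymethyl in place of phenyl gives a number 8.4 percentage points lower from compound 2 to compound 4 (within the scatter), the first step seen at this position on the five-membered aromatic ring. Lengthening the group by this exchange, which also brings in a hydrogen-bond acceptor, therefore gives no change that can be read. Nothing measured here offers an explanation for this result.

From the compounds shown here alone, whether a benzyl group, an amine or a carboxylic acid at this position would give a step beyond the scatter remains open. Also open, going by these compounds, is what phenoxymethyl would do in place of the dimethoxyphenyl group of compound 3.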